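The compounds below may be only part of what the source reports. "The series", "measured", "known", "first", "only" and "open" are said of these compounds alone.

Of the compounds shown here, two have numbers so far in an ADME assay for permeability, using PAMPA, with a stated time of 4 h, at pH 7.4; a higher number here means that the compound crosses the layer faster, a lower number that the compound crosses the layer more slowly. Compound 2 `c1cnc2c(c1)CN[C@@H](CN(CCCCN(C1COC1)C1COC1)[C@H]1CCCc3cccnc31)C2` gives 320 nm/s, the higher of the two and well beyond the usual scatter from compound 1 `NC/C=C/CN(C[C@H]1Cc2ncccc2CN1)[C@H]1CCCc2cccnc21`, which gives 15 nm/s. These two differ in more than one place, so their gap cannot be tied to any single change.

Compound 3 `c1cnc2c(c1)CN[C@@H](CN(CCCC1CCNCC1)[C@H]1CCCc3cccnc31)C2` keeps the core of compound 2 and alters only the far end of the chain: a group of 6 heavy atoms (5 carbon, 1 nitrogen; one six-membered non-aromatic ring with 1 hetero atom) in place of a group of 10 heavy atoms (7 carbon, 1 nitrogen, 2 oxygen; 2 four-membered non-aromatic rings with 1 hetero atom each), on a saturated chain carbon, three bonds along the chain from an amine nitrogen. Going by the values given here, no measured pair shows this change directly, so any expectation here is rough. The piperidin-4-yl group of compound 3 ends in a nitrogen bearing a hydrogen. The chain of compound 1 does too, and compound 1 stands at 15 nm/s. On that single comparison, a clear drop in this assay, beyond the scatter, is expected, though perhaps not all the way down to that level. The expected step is an 8.0-fold lower number from compound 2 to compound 3 (0.90 log units; beyond the scatter). For compound 3 the estimated value is 40 nm/s, with an expected range from 10 nm/s to 150 nm/s.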

Compound 3, apparent permeability: 24 nm/s
Estimate against measurement, compound 3: 1.7-fold (0.22 log units) above, and the stated range covers the measured number.
By their numbers in this assay, from the lowest: compounds 1 and 3 (each within the scatter of the next); then compound 2.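

Going by these compounds alone, this is the first measured step at the far end of the chain, and it shows that the number in this assay can depend strongly on the group placed there: putting piperidin-4-yl in place of the group with 2 four-membered rings gives a 13-fold lower number from compound 2 to compound 3 (1.12 log units; beyond the scatter). The second step compares two chain ends that each finish in a nitrogen bearing a hydrogen: 2-(piperidin-4-yl)ethyl in place of 3-aminoprop-1-en-1-yl gives a 1.6-fold higher number from compound 1 to compound 3 (0.20 log units; within the scatter), so this swap makes no readable difference in this assay. Nothing measured here gives a reason for either step.

The group leaving compound 2 and the group entering compound 3 differ at once in ring size, in heavy atoms and in the hydrogen on nitrogen, so this single pair cannot show which of these differences goes with the large step. A methyl group on the ring nitrogen of piperidin-4-yl, on the same chain, would change only that hydrogen and so would help to separate these differences.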